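Removing the methoxycarbonyl group from compound 2

A few compounds are considered here, and "the series" means these few. Any claim that something is new, unique, unknown or untested is made for them only; others in the source may bear on it.

compound 1 `CSC(=O)c1c(C(C)C)cc(O)c(C)c1O[C@@H]1O[C@H](CO)[C@@H](O)[C@H](O)[C@H]1O`: > 40000 nM (a limit)
compound 2 `COC(=O)c1c(O)c(C)c(O)c(C)c1C(C)C`: > 40000 nM (a limit)

Both compounds were tested in a functional assay on PC-3 cells (Homo sapiens) for cytotoxicity, read by sulforhodamine B assay, with a stated time of 72 h; a higher number here means a weaker inhibitor, a lower number a stronger inhibitor. Compound 2 gives > 40000 nM in this assay, and this is a limit, not a number. It therefore has no exact position, and it shares the limit of > 40000 nM in this assay, at which 2 of the 2 values shown sit, with compound 1.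

The next compound is compound 3 `Cc1c(O)cc(C(C)C)c(C)c1O`, which has hydrogen in place of methoxycarbonyl on an aromatic carbon. The hydrogen sits ortho to a hydroxy group and ortho to an isopropyl group.

Among the measured compounds shown here, no measured pair shows what such a change does, so any forecast is loose. In this assay, only a modest shift toward stronger inhibition is expected, and another limit is quite possible. The expected change is an at least 1.3-fold lower number from compound 2 to compound 3 (0.12 log units; that floor lies within the scatter). The estimated value for compound 3 is 30000 nM, with an expected range of 10000 nM to 80000 nM.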

Compound 3, half-maximal inhibitory concentration: > 40000 nM
Compound 3 was reported as a limit; the forecaster's own chance of this, stated with the estimate: 55%; at least 1.3-fold (0.12 log units) between middle value and limit.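

Compound 2 and compound 3 both give only a limit, not a number, so no step between them can be read: the limit of > 40000 nM in this assay, at which 3 of the 3 values shown sit.

The compounds shown leave open whether hydrogen in place of methoxycarbonyl changes the true strength of inhibition in this assay at all.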